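Shifting the fluorine of compound 1 across the fluorophenyl group

The source may hold more compounds than are shown below. What is called first, only, known or untested is meant among the compounds shown, and "the series" means these compounds.

Compound 1 `Cc1cnc(Nc2ccc(F)cc2)nc1Nc1nc2ccccc2s1` sits at the edge of what a functional assay on HeLa cells (Homo sapiens) for antiproliferative activity, read by MTT assay, with a stated time of 48 h (a lower number here means a stronger inhibitor, a higher number a weaker inhibitor), can report: compound 1 gives > 50000 nM, a limit rather than a number (the limit of > 50000 nM in this assay, at which 1 of the 2 values shown sits). Going by the values given here, compound 2 `Cc1cnc(Nc2ccc(N3CCCCC3)cc2)nc1Nc1nc2ccccc2s1` gives 4340 nM in this assay, and the single measured step, an at least 11-fold lower number from compound 1 to compound 2 (1.06 log units; beyond the scatter), changes the substituent itself, not its place. Compound 3 `Cc1cnc(Nc2cccc(F)c2)nc1Nc1nc2ccccc2s1` differs from compound 1 by 3-fluorophenyl in place of 4-fluorophenyl on a nitrogen on an aromatic ring. Among the compounds with values here, no measured step speaks to such a repositioning, so no change beyond the scatter is expected. Compound 3 is therefore estimated at 50000 nM, within 10000 nM to 250000 nM. The expected step of a number no higher from compound 1 to compound 3 (the limit leaves the size open) keeps it near the limit.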

Compound 3, half-maximal inhibitory concentration: 16300 nM
Compound 3: middle estimate off by 3.1-fold (0.49 log units), on the high side; measured number inside the range.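

In this assay, the same atoms joined differently give an at least 3.0-fold lower number from compound 1 to compound 3 (0.48 log units; beyond the scatter), so replacing 4-fluorophenyl with 3-fluorophenyl on this nitrogen changes the result, whereas the earlier step changed only the substituent itself. The full size of this step cannot be read because compound 1 stands only at a limit: the limit of > 50000 nM in this assay, at which 1 of the 3 values shown sits.

As far as these compounds go, it remains open whether the piperidin-1-yl group of compound 2 would respond to the same repositioning. From the compounds shown here alone, the effect of an amine or a carboxylic acid in place of the fluorine also remains open.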